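A few compounds are considered here, and "the series" means these few. Any claim that something is new, unique, unknown or untested is made for them only; others in the source may bear on it.

Compound 2 `COc1ccc(-n2cc(CO[C@@H]3COc4nc([N+](=O)[O-])cn4C3)nn2)cc1F` belongs to a small set of nitroimidazooxazines that carry an aryl-triazole side chain, and its neighbour compound 1 `O=[N+]([O-])c1cn2c(n1)OC[C@@H](OCc1cn(-c3ccc(F)cc3)nn1)C2` differs from it only in the aryl group on the triazole nitrogen. In an ADME assay on Vero cells (Chlorocebus sabaeus) for cytotoxicity, with a stated time of 72 h (a lower number here means a stronger inhibitor, a higher number a weaker inhibitor), compound 1 reaches only the assay limit of > 128000 nM, so its number is not read. In this assay compound 2 likewise reaches only the limit of > 128000 nM. The step that the two limits leave unreadable from compound 1 to compound 2 is therefore unreadable, and compound 2 stands at the limit shared by every value in the set, as the limit of > 128000 nM in this assay, at which 2 of the 2 values shown sit, shows. Compound 3 `COc1ccc(-n2cc(CO[C@@H]3COc4nc([N+](=O)[O-])cn4C3)nn2)cn1` is the next member; its change from compound 2 is 6-methoxypyridin-3-yl in place of 3-fluoro-4-methoxyphenyl on an aromatic nitrogen. For the measured compounds named here, no measured step bears readably on this change, and the only evidence is that both measured compounds sit at the limit. The expected step that the limit leaves unreadable from compound 2 to compound 3 is therefore none beyond the scatter, and compound 3 is expected to give 200000 nM, in a range from 100000 nM to 600000 nM.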

Compound 3, half-maximal inhibitory concentration: > 128000 nM
Compound 3 was reported as a limit; the forecaster's own chance of this, stated with the estimate: 90%; the middle value lies beyond the limit too.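

In this assay compound 3 gives > 128000 nM, a limit of the assay and not a number. No step from compound 1 or compound 2 to compound 3 can be read: the limit of > 128000 nM in this assay, at which 3 of the 3 values shown sit.

The compounds shown leave open whether changing the aryl group on the triazole nitrogen alters the result in this assay at all.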